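The source may report more compounds than this note shows. Statements on the series, on what has been measured and on what is new or still open speak of the compounds shown alone.

Of the compounds shown here, two have been measured in an assay for inhibition of protein disulfide-isomerase (Homo sapiens), with a stated time of 1 h; a higher number here means a weaker inhibitor, a lower number a stronger inhibitor. Compound 1 `Oc1c(C(c2ccc(F)cc2)N2CCCCC2)ccc2c1OCCO2` gives 290 nM in this assay. Compound 2 `Cc1ccc(C)c(C(Nc2ccccn2)c2ccc3cccnc3c2O)c1` gives 730 nM in this assay, the higher of the two numbers, and the gap to compound 1 lies beyond the usual scatter of repeated measurements. The two structures differ in several places at once. For the measured compounds named here, the numbers alone show only that compound 2 is the weaker inhibitor of the pair; they do not tell which part of the structure is responsible.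

Compound 3 `Cc1cc(C)c(C(Nc2ccccn2)c2ccc3cccnc3c2O)c(C)c1` has not yet been measured. It is derived from compound 2 by a single change: 2,4,6-trimethylphenyl in place of 2,5-dimethylphenyl on a saturated chain carbon bound to an aromatic carbon and a nitrogen on an aromatic ring. Going by the values given here, no measured pair in this set differs in only one place, so there is no measured step to lean on for the size of this one. The change is small and keeps the same kind of ring, so the step from compound 2 to compound 3 is expected to be modest, a 1.1-fold higher number from compound 2 to compound 3 (0.04 log units; within the scatter), with no clear direction. Compound 3 is therefore estimated to give about 800 nM in this assay, within a range from 300 nM to 2500 nM.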

Compound 3, half-maximal inhibitory concentration: 190 nM
The estimate for compound 3 lay 4.2-fold (0.62 log units) above the measured number; the measured number lies below the stated range.
By their numbers in this assay, from the lowest: compounds 3 and 1 (each within the scatter of the next); then compound 2.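

The swap of 2,5-dimethylphenyl for 2,4,6-trimethylphenyl, on a saturated chain carbon bound to an aromatic carbon and a nitrogen on an aromatic ring, gives a 3.8-fold lower number from compound 2 to compound 3 (0.58 log units; beyond the scatter) in this assay. This is the only change in one place among these compounds, and it shows that this position responds to a small edit: the ring stays six-membered, aromatic and made of carbon only, the group goes from 8 heavy atoms to 9, and neither group has hydrogen-bond donors, hydrogen-bond acceptors or a net charge. No measurement is available that explains why a change this small moves the number this far.

The compounds shown leave open whether the total of methyl groups or their arrangement on the ring matters, and whether a different group at this place, such as a methoxy group, a chlorine atom or a carboxylic acid on the phenyl ring, would keep the lower number. For the compounds shown here, compound 1 is joined to neither of the other two compounds by a change in one place, so no step to it can be read.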